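Difluoromethoxy for trifluoromethyl on the shared core

The source may hold more compounds than are shown below. What is called first, only, known or untested is meant among the compounds shown, and "the series" means these compounds.

Measured so far:
Compound 1, `CCCCOc1ccc(Nc2nc3nonc3nc2O)cc1`: 3700 nM
Compound 2, `CC(=O)c1ccc(Nc2nc3nonc3nc2O)cc1`: 93700 nM
Compound 3, `Oc1nc2nonc2nc1Nc1ccc(C(F)(F)F)cc1`: 10400 nM

These three compounds share one core and differ only in the group on the aromatic ring. In an assay on mitochondria from L6 cells (Rattus norvegicus) for activation, with a stated time of 90 min (a higher number here means that more compound is needed for the effect, a lower number that less compound is needed), compound 1 gives the lowest number, compound 2 the highest, and compound 3 stands second highest: its nearest neighbour is compound 1, a 2.8-fold higher number from compound 1 to compound 3 (0.45 log units; beyond the scatter), while its furthest is compound 2, a 9.0-fold lower number from compound 2 to compound 3 (0.95 log units; beyond the scatter). The swing across the set is wide, a 25-fold higher number from compound 1 to compound 2 (1.40 log units; beyond the scatter).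

Compound 4, `Oc1nc2nonc2nc1Nc1ccc(OC(F)F)cc1`, has not been measured. difluoromethoxy in place of trifluoromethyl on an aromatic carbon

Among the compounds with values here, no measured step makes exactly this change. The step from compound 1 to compound 3 is the closest, since it exchanged an oxygen-linked butoxy for trifluoromethyl and gave a 2.8-fold higher number from compound 1 to compound 3 (0.45 log units; beyond the scatter). Difluoromethoxy is again oxygen-linked, so a modest step back toward compound 1 is expected, though not necessarily beyond the scatter. Compound 4 is therefore estimated at 5500 nM in this assay, within 1800 nM to 17000 nM, which means an expected step of a 1.9-fold lower number from compound 3 to compound 4 (0.28 log units; within the scatter).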

Compound 4, half-maximal effective concentration: 20600 nM
For compound 4 the middle estimate is 3.7-fold (0.57 log units) below the measured one; measured number outside the range, above it.
By their numbers in this assay, from the lowest: compound 1; then compounds 3 and 4 (each within the scatter of the next); then compound 2.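

In this assay, difluoromethoxy in place of trifluoromethyl gives a 2.0-fold higher number from compound 3 to compound 4 (0.30 log units; within the scatter), so at this position the two groups cannot be told apart, even though the entering group has an oxygen linked to the aromatic ring and one hydrogen-bond acceptor, and the leaving group has neither. Having that oxygen is therefore not enough to match compound 1: difluoromethyl in place of butyl on the oxygen gives a 5.6-fold higher number from compound 1 to compound 4 (0.75 log units; beyond the scatter), while difluoromethoxy in place of acetyl gives a 4.5-fold lower number from compound 2 to compound 4 (0.66 log units; beyond the scatter), which places compound 4 clearly apart from both of these neighbours. Nothing available for these compounds goes beyond the assay numbers, so the reason for these steps remains unexplained.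

Still open, going by these compounds, is whether the number follows the length of the chain on the oxygen, which methoxy, ethoxy or hexyloxy groups at this position would help to show. Also open, on these data alone, is how an amine or a carboxylic acid would compare here, and whether these steps would hold with a change elsewhere on the shared core, which stays the same in all four compounds.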